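Removing a Chloro Group from Two Benzylpurine Cores

A few compounds are considered here, and "the series" means these few. Any claim that something is new, unique, unknown or untested is made for them only; others in the source may bear on it.

Compound 1 `ClCc1ccccc1Cn1cnc2c(Cl)nc(Cl)nc21` gives 310 nM in a functional assay on U-251 cells (Homo sapiens) for cytotoxicity, read by sulforhodamine B assay, with a stated time of 48 h; a higher number here means a weaker inhibitor of growth, a lower number a stronger inhibitor of growth. Compound 2 `ClCc1ccccc1Cn1cnc2c(Cl)ncnc21` differs from it by a single change, (hydrogen in place of chloro on an aromatic carbon), and in this assay compound 2 gives 2630 nM. Going by the values given here, the step of an 8.5-fold higher number from compound 1 to compound 2 (0.93 log units; beyond the scatter) is the only measured instance of this change so far. Compound 3 `ClCc1ccc(Cn2cnc3nc(Cl)nc(Cl)c32)cc1` is built from the same atoms as compound 1, joined differently; the difference between the two cores is not broken down here. In this assay compound 3 gives 1770 nM, which lies within the usual scatter of compound 2 and beyond it relative to compound 1.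

Compound 4 `ClCc1ccc(Cn2cnc3ncnc(Cl)c32)cc1` differs from compound 3 by hydrogen in place of chloro on an aromatic carbon, a change that occurs twice among these four compounds and whose place is described in the same words as for the pair of compound 1 and compound 2. Among the compounds with values here, since the only measured instance is an 8.5-fold higher number from compound 1 to compound 2 (0.93 log units; beyond the scatter), a step of a similar size is expected from compound 3 to compound 4, namely a 6.8-fold higher number from compound 3 to compound 4 (0.83 log units; beyond the scatter), with some extra uncertainty because the two cores differ. Compound 4 is therefore expected to give about 12000 nM in this assay, most likely between 4000 nM and 40000 nM.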

Compound 4, concentration for 50% growth inhibition: 1090 nM
Compound 4: middle estimate off by 11-fold (1.04 log units), on the high side; measured number outside the range, below it.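

In this assay, replacing the chloro group between two ring nitrogen atoms with hydrogen gives a 1.6-fold lower number from compound 3 to compound 4 (0.21 log units; within the scatter), which does not repeat the clear loss of growth inhibition seen on the core of compound 1. Set side by side, the two results show that this change does not carry over between the two cores: the same change on two cores in this assay, an 8.5-fold higher number (0.93 log units; beyond the scatter) from compound 1 to compound 2 and a 1.6-fold lower number (0.21 log units; within the scatter) from compound 3 to compound 4, 14-fold (1.14 log units) apart, beyond the scatter of two such steps

Within these four compounds, the effect of the change therefore depends on the core that carries it, but with only one pair on each core, the data do not show which difference between the cores is responsible or how either step would read on a further core.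

The compounds shown leave open whether an amine or a methoxy group at the same place would follow the pair of compound 1 and compound 2 or the pair of compound 3 and compound 4. They also leave open how growth inhibition on either core would respond if an amine took the place of the remaining chloro group on the ring.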